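Swapping the aniline ring on a urea-linked pyrimidine core

A few compounds are considered here, and "the series" means these few. Any claim that something is new, unique, unknown or untested is made for them only; others in the source may bear on it.

Measured so far:
compound 1, `COc1ccc(C(F)(F)F)cc1Nc1cc(NC(=O)Nc2c(Cl)cccc2Cl)ncn1`, 89%
compound 2, `COc1cc(NC(=O)Nc2cc(Nc3ccc(C)c(F)c3)ncn2)cc(OC)c1`, 77.5%

Of the compounds shown here, two have been measured in a functional assay on PC-9 cells (Homo sapiens) for inhibition, read by MTT assay, with a stated time of 48 h, tested at 10 uM; a lower number here means less inhibition, a higher number more inhibition at the concentration tested (going by the name of the read-out). Compound 1 reaches 89%, while compound 2 gives 77.5%, the lower of the two numbers, with compound 1 sitting higher by a margin beyond the usual scatter. Compound 3, `COc1cc(NC(=O)Nc2cc(Nc3ccc(F)c(Cl)c3)ncn2)cc(OC)c1`, has not yet been measured. It differs from compound 2 in a single place, (3-chloro-4-fluorophenyl in place of 3-fluoro-4-methylphenyl on a nitrogen on an aromatic ring). The aryl group that leaves and the one that enters hold the same number of heavy atoms, the same single aromatic ring, and neither donates nor accepts hydrogen bonds, so the change is a modest one. Going by the values given here, no measured pair shows the effect of such a swap, so the expectation rests on compound 2 alone. The step of a number 0.5 percentage points higher from compound 2 to compound 3 (within the scatter) is expected to stay within the scatter. Compound 3 is therefore estimated at 78%, with a range from 58% to 92%.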

Compound 3, a percentage reported as inhibition, at one concentration (the size of the read-out at that concentration, not a potency): 77.5%
Compound 3: middle estimate off by 0.5 percentage points, on the high side, within the range that was stated.
By their numbers in this assay, from the lowest: compounds 2 and 3 (each within the scatter of the next); then compound 1.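

Placing 3-chloro-4-fluorophenyl in place of 3-fluoro-4-methylphenyl on a nitrogen on an aromatic ring gives no change at the digits printed from compound 2 to compound 3 (within the scatter) in this assay. Going by these compounds alone, this is the first direct reading at this position, and it shows that one aryl group can be exchanged for the other, with the same count of heavy atoms, without a measurable shift in inhibition at the single concentration tested. Nothing available explains why the two groups give matching numbers.

From the compounds shown here alone, whether a different kind of group at this position, such as a phenyl ring carrying a carboxylic acid or an amine, would give a higher, lower or level number remains open. Compound 1 differs from compound 2 in more than one place, so its higher number cannot be assigned to any single group.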